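From 3-aminopropyl to 2-aminoethoxy on the amine chain

The source may hold more compounds than are shown below. What is called first, only, known or untested is meant among the compounds shown, and "the series" means these compounds.

In a functional assay on EJ cells (Homo sapiens) for cytotoxicity, read by MTT assay, with a stated time of 48 h (a lower number here means a stronger inhibitor, a higher number a weaker inhibitor), compound 1 `CC(C)=CCC/C(C)=C/CC/C(C)=C/CSc1ccccc1C(=O)NCCCN` gives 17200 nM, compound 2 `CC(C)=CCC/C(C)=C/CC/C(C)=C/CSc1ccccc1C(=O)NCCCCN` gives 13100 nM and compound 3 `CC(C)=CCC/C(C)=C/CC/C(C)=C/CSc1ccccc1C(=O)NCCCCCN` gives 9850 nM. These three share one core and differ only in the length of the chain that ends in the amine. Compound 3 cannot be told apart from the other two, since each measured step stays within the scatter: a 1.3-fold lower number from compound 1 to compound 2 (0.12 log units; within the scatter), a 1.3-fold lower number from compound 2 to compound 3 (0.12 log units; within the scatter) and a 1.7-fold lower number from compound 1 to compound 3 (0.24 log units; within the scatter).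

Compound 4 `CC(C)=CCC/C(C)=C/CC/C(C)=C/CSc1ccccc1C(=O)NCCOCCN` keeps the same core and changes the chain: 2-aminoethoxy in place of 3-aminopropyl on a saturated chain carbon, two bonds along the chain from an amide-type nitrogen. Within the data shown here, no measured step makes this kind of swap. All three only lengthen the chain, so they are indirect evidence. Even so, the chain changes ending at compound 3 were small, at a 1.7-fold lower number from compound 1 to compound 3 (0.24 log units; within the scatter), and no shift beyond the scatter is expected in this assay. The expected result is a 1.2-fold higher number from compound 3 to compound 4 (0.09 log units; within the scatter). For compound 4 the estimated value is 12000 nM, with an expected range from 6000 nM to 24000 nM.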

Compound 4, half-maximal inhibitory concentration: 6130 nM
Compound 4: the middle estimate sits 2.0-fold (0.29 log units) above what was measured; low and high end bracket the measured number.
By their numbers in this assay, from the lowest: compounds 4, 3, 2 and 1 (each within the scatter of the next, the first and the last beyond it).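

Swapping 3-aminopropyl for 2-aminoethoxy, two bonds along the chain from an amide-type nitrogen, gives a 1.6-fold lower number from compound 3 to compound 4 (0.21 log units; within the scatter), so an oxygen can stand in this chain without a change that this assay can resolve from compound 3. Compound 4 does open the first gaps in this set that lie beyond the scatter, though both are modest: a 2.1-fold lower number from compound 2 to compound 4 (0.33 log units; beyond the scatter) and a 2.8-fold lower number from compound 1 to compound 4 (0.45 log units; beyond the scatter). Nothing shown here explains these numbers, so the part played by the oxygen, as distinct from chain length, remains unsettled.

A sulfur atom in place of the chain oxygen would help test whether oxygen itself matters. As far as these compounds go, a longer chain with further ether oxygens, or a carboxylic acid in place of the amine, also remains open in this assay.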